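The source may report more compounds than this note shows. Statements on the series, on what has been measured and on what is new or still open speak of the compounds shown alone.

Three compounds share one core and differ only in the group carried on a triple-bonded carbon. In an assay on CHO cells for displacement of a labelled ligand from adenosine receptor A1 (Homo sapiens), read by scintillation counting, with a stated time of 60 min, tested at 10 uM (on this read-out lower numbers stand for less inhibition and higher numbers for more inhibition at the one concentration tested (going by the name of the read-out)), compound 1 `CNC(=O)[C@@]12C[C@@H]1[C@@H](n1cnc3c(NC)nc(C#Cc4ccccc4)nc31)[C@H](O)[C@@H]2O` gives 18%. In this assay compound 2 `CNC(=O)[C@@]12C[C@@H]1[C@@H](n1cnc3c(NC)nc(C#Cc4ccc(CO)cc4)nc31)[C@H](O)[C@@H]2O` gives 16%, and compound 3 `CNC(=O)[C@@]12C[C@@H]1[C@@H](n1cnc3c(NC)nc(C#Cc4cccnc4)nc31)[C@H](O)[C@@H]2O` gives 16%. Compound 3 thus stands level with compound 2 at the digits reported, the two together the lowest of the three numbers, with compound 1 the furthest away: the step of a number 2 percentage points lower from compound 1 to compound 3 (within the scatter) and the step of no change at the digits printed from compound 2 to compound 3 (within the scatter) both lie within the scatter, as does the step of a number 2 percentage points lower from compound 1 to compound 2 (within the scatter). None of the three exchanges on the triple-bonded carbon moves the read-out beyond what repeated measurement would show.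

Compound 4 `CNC(=O)[C@@]12C[C@@H]1[C@@H](n1cnc3c(NC)nc(C#Cc4cnn(C)c4)nc31)[C@H](O)[C@@H]2O` is the next member of the set. The change from compound 3 is 1-methyl-1H-pyrazol-4-yl in place of pyridin-3-yl on a triple-bonded carbon. For the measured compounds named here, the steps that bear on it are those that also exchange the group on the triple-bonded carbon, namely from compound 1 to compound 3 and from compound 2 to compound 3, and both were within the scatter. A step of similar size is therefore expected here, a number 1 percentage points lower from compound 3 to compound 4 (within the scatter), with no direction beyond the scatter. Compound 4 is expected to give about 15%, within a range from 5% to 27%.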

Compound 4, a percentage reported as inhibition, at one concentration (the size of the read-out at that concentration, not a potency): 35%
Estimate against measurement, compound 4: 20 percentage points below; the measured number lies above the stated range.
By their numbers in this assay, from the lowest: compounds 2, 3 and 1 (each within the scatter of the next); then compound 4.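

In this assay, the place on the triple-bonded carbon proves not to be indifferent to the group it carries: 1-methyl-1H-pyrazol-4-yl gives a number 19 percentage points higher from compound 3 to compound 4 (beyond the scatter), and the same group gives a number 19 percentage points higher from compound 2 to compound 4 (beyond the scatter) and a number 17 percentage points higher from compound 1 to compound 4 (beyond the scatter). Phenyl, 4-(hydroxymethyl)phenyl and pyridin-3-yl, each with a six-membered aromatic ring, had all stayed within the scatter of one another, so this five-membered aromatic ring with 2 hetero atoms is the first group here to move the read-out beyond it, and it does so with the same count of heavy atoms as pyridin-3-yl. Nothing measured here ties the rise to any feature of the group.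

Still open, from the compounds shown here alone, is whether the rise goes with the five-membered ring, its second ring nitrogen or its methyl, since pyridin-3-yl and 1-methyl-1H-pyrazol-4-yl differ in all three at once, and a single five-membered example cannot separate them. Also open, going by these compounds, is how the read-out would respond to 1H-pyrazol-4-yl without the methyl, to thiazol-5-yl, or to a longer alkyl chain in place of that methyl.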